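This account rests on a few compounds, and the source may have more. Where it says the series, first, only, none or still open, it means among the compounds named here.

Compound 2 `COc1ccc(Nc2nc(SCc3ccc(C(F)(F)F)cc3)nc3ccccc23)cc1` was measured in a functional assay on PC-3 cells (Homo sapiens) for cytotoxicity, read by MTT assay, with a stated time of 72 h (a lower number here means a stronger inhibitor, a higher number a weaker inhibitor), where compound 2 gives 16700 nM. Among the measured compounds shown here, its only measured neighbour, compound 1 `FC(F)(F)c1ccc(CSc2nc(N3CCCCC3)c3ccccc3n2)cc1`, gives 25500 nM, and the step of a 1.5-fold lower number from compound 1 to compound 2 (0.18 log units; within the scatter) concerns a different group on a different part of the molecule. Compound 3 `COc1ccc(Nc2nc(SCc3ccc(C(F)(F)F)cc3)nc3ccccc23)c(OC)c1` differs from compound 2 by methoxy in place of hydrogen on an aromatic carbon. No measured step adds a methoxy, so nothing shown points to a shift beyond the scatter in this assay. Compound 3 is therefore expected to give 16000 nM, within a range from 6000 nM to 45000 nM, an expected step of a 1.0-fold lower number from compound 2 to compound 3 (0.02 log units; within the scatter).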

Compound 3, half-maximal inhibitory concentration: 32500 nM
The estimate for compound 3 lay 2.0-fold (0.31 log units) below the measured number, within the range that was stated.
By their numbers in this assay, from the lowest: compounds 2, 1 and 3 (each within the scatter of the next).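

In this assay, the first added methoxy on the aniline ring, ortho to a large group, gives a 1.9-fold higher number from compound 2 to compound 3 (0.29 log units; within the scatter), so this position accepts the change without a shift beyond the scatter. Replacing piperidin-1-yl with (2,4-dimethoxyphenyl)amino likewise gives a 1.3-fold higher number from compound 1 to compound 3 (0.11 log units; within the scatter). No measurement here explains either step. Still open, as far as these compounds go, is whether an amine or a carboxylic acid at this position would give a step beyond the scatter. A longer chain, such as ethoxy, also remains to be compared with methoxy.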